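The source may report more compounds than this note shows. Statements on the series, on what has been measured and on what is new or still open speak of the compounds shown alone.

Compound 1, `N#Cc1ccc(Nc2nccc(Oc3ccc(-c4ccc(C#N)c(Cl)c4)cc3Cl)n2)cc1`, is one of two compounds tested in a functional assay on MT4 cells (Homo sapiens) for cytotoxicity, read by MTT assay, with a stated time of 5 days (a lower number here means that less compound is tolerated, a higher number that more compound is tolerated), where compound 1 gives 14900 nM. Compound 2, `N#Cc1ccc(Nc2nccc(Oc3ccc(-c4ccc(C#N)cc4)cc3Cl)n2)cc1`, differs from it only by a hydrogen in place of a chloro group on an aromatic carbon. In this assay compound 2 reaches only a limit of the assay, > 295000 nM, so no exact number is known for it. The step of an at least 19-fold higher number from compound 1 to compound 2 (1.29 log units; beyond the scatter) is therefore a lower bound on how much more of compound 2 the cells tolerate, and the limit of > 295000 nM in this assay, at which 1 of the 2 values shown sits, marks the edge that compound 2 sits on.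

Compound 3, `COc1cc(-c2ccc(C#N)cc2)ccc1Oc1ccnc(Nc2ccc(C#N)cc2)n1`, is not yet measured. Compared with compound 2, (methoxy in place of chloro on an aromatic carbon). Within the data shown here, the only measured step available is the one from compound 1 to compound 2, which removed a chloro group and moved the number to the top of the measurable range. The change toward compound 3 again leaves the chloro-free position without a chloro group, so a similar, very high reading is expected rather than a return toward compound 1. Compound 3 is estimated at 300000 nM, between 100000 nM and 700000 nM, which as a step from compound 2 means a step that the limit leaves unreadable from compound 2 to compound 3 and most likely again only a limit.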

Compound 3, half-maximal cytotoxic concentration: > 298000 nM
Compound 3 gave a limit, no number; the forecaster's own chance of this, stated with the estimate: 70%; the middle value lies beyond the limit too.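

In this assay compound 3 gives > 298000 nM, which is a limit of the assay and not a number. Among these compounds, compound 2 also stands at a limit, so no step between compound 2 and compound 3 can be read. The compounds shown leave open whether methoxy in place of chloro changes how much compound the cells tolerate.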